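Bis-enone phenols: aryl substituent change at the para position

The source may hold more compounds than are shown below. What is called first, only, known or untested is meant among the compounds shown, and "the series" means these compounds.

Measured so far:
- compound 2 `Cc1cc(O)c(C(=O)/C=C/c2ccccc2)c(-c2ccc(Br)cc2)c1C(=O)/C=C/c1ccccc1`: 30000 nM
- compound 1 `Cc1cc(O)c(C(=O)/C=C/c2ccccc2)c(-c2ccccc2)c1C(=O)/C=C/c1ccccc1`: "not active" (no number reported)

Going by the values given here, in a functional assay on HeLa cells (Homo sapiens) for cytotoxicity, read by MTT assay, with a stated time of 24 h (a higher number here means a weaker inhibitor, a lower number a stronger inhibitor), compound 2 gives 30000 nM and is the only compound of the pair with a number; compound 1 returns no number. Compound 3 `Cc1cc(O)c(C(=O)/C=C/c2ccccc2)c(-c2ccc(OCc3ccccc3)cc2)c1C(=O)/C=C/c1ccccc1` carries benzyloxy in place of bromo on an aromatic carbon. Among the compounds with values here, no step between two measured compounds is available to calibrate this change, so no direction can be taken from the series. The step from compound 2 to compound 3 is expected to stay within the usual scatter, no change at the digits printed from compound 2 to compound 3 (within the scatter). Compound 3 is therefore estimated at 30000 nM, with a range from 10000 nM to 100000 nM.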

Compound 3, half-maximal inhibitory concentration: "not active" (no number reported)
For compound 3 the study gives words and no number; no gap can be computed for the estimate.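

Going by these compounds alone, compound 3, like compound 1, gives no number, so no step from compound 2 can be read. Nothing available bears on this result. The compounds shown leave open how far changing the aryl substituent shifts cytotoxicity.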